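A few compounds are considered here, and "the series" means these few. Any claim that something is new, unique, unknown or untested is made for them only; others in the source may bear on it.

In an ADME assay on L6 cells (Rattus norvegicus) for cytotoxicity, read by resazurin assay, with a stated time of 70 h (a higher number here means a weaker inhibitor, a lower number a stronger inhibitor), compound 1 `N=C(N)c1ccc2cc(-c3cccc(OCCCOc4ccccc4)c3)oc2c1` gives 19800 nM. Compound 2 `CC(C)NC(=N)c1ccc2cc(-c3cccc(OCCCOc4ccccc4)c3)oc2c1` carries isopropyl in place of hydrogen on an amine nitrogen, and in this assay compound 2 gives 82300 nM, so the step is a 4.2-fold higher number from compound 1 to compound 2 (0.62 log units; beyond the scatter). Compound 3 `N=C(N)c1ccc2oc(-c3ccc(OCCCOc4ccccc4)cc3)cc2c1` is built from the same atoms as compound 1, joined differently; the difference between the two cores is not broken down here. In this assay compound 3 gives 7300 nM, the lowest of the three numbers, beyond the scatter from compound 1 and further still from compound 2.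

Compound 4 `CC(C)NC(=N)c1ccc2oc(-c3ccc(OCCCOc4ccccc4)cc3)cc2c1` has not yet been measured. It differs from compound 3 by isopropyl in place of hydrogen on an amine nitrogen, the same change as from compound 1 to compound 2, at a place described in the same words: an amine nitrogen whose other neighbour is a carbon with a double bond to nitrogen. On the strength of a 4.2-fold higher number from compound 1 to compound 2 (0.62 log units; beyond the scatter) a step of similar size is expected in this assay: a 4.1-fold higher number from compound 3 to compound 4 (0.61 log units; beyond the scatter). Since compound 3 gives 7300 nM, the number for compound 4 is expected to be higher. Compound 4 is estimated at 30000 nM, and is expected to fall between 15000 nM and 60000 nM.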

Compound 4, half-maximal inhibitory concentration: 45600 nM
Estimate against measurement, compound 4: 1.5-fold (0.18 log units) below; low and high end bracket the measured number.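

In this assay, isopropyl in place of hydrogen on an amine nitrogen again gives a higher number, a 6.2-fold higher number from compound 3 to compound 4 (0.80 log units; beyond the scatter), so the change points the same way on the second core as on the first. The two steps agree in size as far as these measurements can tell: the same change on two cores in this assay, a 4.2-fold higher number (0.62 log units; beyond the scatter) from compound 1 to compound 2 and a 6.2-fold higher number (0.80 log units; beyond the scatter) from compound 3 to compound 4, 1.5-fold (0.18 log units) apart, within the scatter of two such steps. Among these compounds, this shows that the change carried over between these two cores in this assay, but it rests on only two pairs of compounds and does not show that it would carry over to any other core, nor does it explain why the number rises.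

The compounds shown leave open whether a methyl, an ethyl or a tert-butyl group on the same amine nitrogen would give a step of similar size. On these data alone, it also remains open whether the step would hold on a core that carries a carboxylic acid or a longer chain.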